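Pyridin-3-yl in place of methyl on the ring nitrogen

A few compounds are considered here, and "the series" means these few. Any claim that something is new, unique, unknown or untested is made for them only; others in the source may bear on it.

Measured compounds:
Compound 1 `O=C1/C(=C/N2N=C(c3ccccc3)CC2c2ccccc2O)SC(=S)N1c1cccnc1` gives 720 nM in a functional assay on HL-60 cells (Homo sapiens) for antiproliferative activity, read by MTT assay, with a stated time of 72 h; on this read-out higher numbers stand for weaker inhibition and lower numbers for stronger inhibition.
Compound 2 `CN1C(=O)/C(=C/N2N=C(c3ccc4ccccc4c3)CC2c2ccccc2O)SC1=S` gives > 10000 nM in this assay.

Compound 1 and compound 2 share a core that differs only at the amide-type nitrogen of the five-membered ring and at the aryl group on the pyrazoline. The value of compound 2 in this assay is not a number but a limit of the assay, as the limit of > 10000 nM in this assay, at which 1 of the 2 values shown sits, records. Compound 1 carries a pyridin-3-yl on that nitrogen and sits well inside the measured range.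

Compound 3 `O=C1/C(=C/N2N=C(c3ccc4ccccc4c3)CC2c2ccccc2O)SC(=S)N1c1cccnc1` is not yet measured. It differs from compound 2 by pyridin-3-yl in place of methyl on an amide-type nitrogen in a ring. Since compound 1, which also bears pyridin-3-yl at that position, gives 720 nM, the step from compound 2 to compound 3 is expected to move toward stronger inhibition, beyond the scatter, by roughly an at least 5.0-fold lower number from compound 2 to compound 3 (0.69 log units; beyond the scatter). Compound 3 is therefore estimated at 2000 nM, within 500 nM to 10000 nM.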

Compound 3, half-maximal inhibitory concentration: 4060 nM
Beside the measured number, compound 3's estimate is 2.0-fold (0.31 log units) below it; low and high end bracket the measured number.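

In this assay, with naphthalen-2-yl held in place, pyridin-3-yl in place of methyl on the amide-type nitrogen gives an at least 2.4-fold lower number from compound 2 to compound 3 (0.39 log units; beyond the scatter) and so brings a naphthalen-2-yl compound inside the measured range. With pyridin-3-yl held on that nitrogen, naphthalen-2-yl in place of phenyl gives a 5.6-fold higher number from compound 1 to compound 3 (0.75 log units; beyond the scatter) and so the gain at the nitrogen does not carry compound 3 to the level of compound 1. Compound 2 is recorded only as a limit, so the step at the nitrogen has a floor and no exact size: the limit of > 10000 nM in this assay, at which 1 of the 3 values shown sits.

The compounds shown leave open whether pyridin-3-yl would give a similar step over methyl with phenyl on the carbon with a double bond to nitrogen. They also leave open how a longer alkyl chain, an acetic acid group or a plain phenyl on the amide-type nitrogen would read in this assay against pyridin-3-yl.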